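A few compounds are considered here, and "the series" means these few. Any claim that something is new, unique, unknown or untested is made for them only; others in the source may bear on it.

Of the compounds shown here, two have so far been measured in a functional assay on K562 cells (Homo sapiens) for antiproliferative activity, with a stated time of 4 days; a lower number here means a stronger inhibitor, a higher number a weaker inhibitor. Compound 1 `CCCCCCCCn1cc(C(=O)O)c(=O)[nH]c1=O` gives 247000 nM, and compound 2 `CCCCNC(=O)c1cn(C)c(=O)[nH]c1=O` gives 536000 nM. Compound 1 therefore stands as the lower of the two numbers, and the gap between them lies beyond the usual scatter. Compound 3 `CCCCCCCCn1cc(C(=O)NCc2ccccc2)c(=O)[nH]c1=O` differs from compound 1 in one place, with benzylamino in place of hydroxy on a carbonyl carbon. For the measured compounds named here, the two measured compounds differ in more than one place, so no measured step shows the size of this change, and any forecast remains loose. A moderate step towards a lower number in this assay is expected, beyond the scatter but with wide uncertainty. The expected change is a 4.1-fold lower number from compound 1 to compound 3 (0.61 log units; beyond the scatter). For compound 3, the estimated value is 60000 nM, with an expected range of 12000 nM to 250000 nM.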

Compound 3, half-maximal inhibitory concentration: 75000 nM
The estimate for compound 3 lay 1.3-fold (0.10 log units) below the measured number, within the range that was stated.
By their numbers in this assay, from the lowest: compound 3; then compound 1; then compound 2.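

In this assay, for the compounds shown here, the change from hydroxy to benzylamino on a carbonyl carbon gives a 3.3-fold lower number from compound 1 to compound 3 (0.52 log units; beyond the scatter) and is the first step measured at this position. It shows that this place accepts the loss of the hydroxy and the entry of a six-membered aromatic ring of carbon only, with the number moving towards stronger inhibition while the rest of the core of compound 1 and its octyl chain stay the same. No evidence at hand accounts for this step.

The compounds shown leave open whether the step follows from the amide itself or from its aromatic ring, which a methylamino or cyclohexylmethylamino group in the same place would separate. They also leave open how far the ring can lie from the carbonyl carbon, as phenethylamino would test.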